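This account rests on a few compounds, and the source may have more. Where it says the series, first, only, none or still open, it means among the compounds named here.

Three compounds have been measured in an ADME assay on the whole organism for pharmacokinetics, with Rattus norvegicus as the target, at a dose of 3 mg/kg by the oral route (a higher number here means more compound in the circulation at the dose given, a lower number less compound in the circulation), so far:

- compound 1 `COC(=O)N[C@H](C(=O)N1CCC[C@H]1C(=O)Nc1ccc([C@H]2CC[C@H](c3ccc(NC(=O)[C@@H]4CCCN4C(=O)[C@@H](NC(=O)OC)C(C)C)cc3)N2c2ccc(C(F)(F)F)cc2)cc1)C(C)C` gives 221 nM
- compound 2 `COC(=O)N[C@H](C(=O)N1CCC[C@H]1C(=O)Nc1ccc([C@H]2CC[C@H](c3ccc(NC(=O)[C@@H]4CCCN4C(=O)[C@@H](NC(=O)OC)C(C)(C)C)cc3)N2c2ccc(F)cc2)cc1)C(C)(C)C` gives 1090 nM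
- compound 3 `COC(=O)N[C@H](C(=O)N1CCC[C@H]1C(=O)Nc1ccc([C@H]2CC[C@H](c3ccc(NC(=O)[C@@H]4CCCN4C(=O)[C@@H](NC(=O)OC)[C@@H](C)OC)cc3)N2c2ccc(F)cc2)cc1)[C@@H](C)OC` gives 135 nM

Compound 2 stands highest of the three, and both of the others lie lower by more than the scatter of repeated measurements. Compound 1 is its nearest neighbour, and compound 3 lies furthest from it.

The next compound to be measured is compound 4 `COC(=O)N[C@H](C(=O)N1CCC[C@H]1C(=O)Nc1ccc([C@@H]2CC[C@@H](c3ccc(NC(=O)[C@@H]4CCCN4C(=O)[C@@H](NC(=O)OC)C(C)(C)C)cc3)N2c2ccc(F)cc2)cc1)C(C)(C)C`, which departs from compound 2 in configuration alone: the two compounds have the same atoms and bonds and differ only in configuration as drawn: 2 of 6 stereo elements differ; a stereocentre at a saturated ring carbon is drawn R in compound 2 and S in compound 4; a stereocentre at a saturated ring carbon is drawn R in compound 2 and S in compound 4. The two compounds have the same atoms and bonds, and at each of the two saturated ring carbons concerned the stereocentre is drawn R in compound 2 and S in compound 4.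

Going by the values given here, the measured compounds offer no pair that differs in one place, so nothing here shows directly how much such a change moves this assay. Compound 2 at 1090 nM is the top value of a small set, so a modest fall is expected rather than a rise, though a result within the scatter would not surprise. The expected outcome is a 1.6-fold lower number from compound 2 to compound 4 (0.19 log units; within the scatter) as an estimate, with wide uncertainty. For compound 4 the estimated value is 700 nM, with an expected range from 200 nM to 2000 nM.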

Compound 4, maximal plasma concentration in the Rattus norvegicus assay: 124 nM
Compound 4: middle estimate off by 5.6-fold (0.75 log units), on the high side; measured number outside the range, below it.
By their numbers in the Rattus norvegicus assay, from the lowest: compounds 4, 3 and 1 (each within the scatter of the next); then compound 2.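

In the Rattus norvegicus assay, compounds 2 and 4 form the only pair among those shown that differs in one place, and inverting the two saturated ring carbons from R to S gives an 8.8-fold lower number from compound 2 to compound 4 (0.94 log units; beyond the scatter). In a physicochemical assay for lipophilicity, read by HPLC, at pH 7.4 (on this read-out lower numbers stand for lower lipophilicity and higher numbers for higher lipophilicity), the same pair reads no change at the digits printed from compound 2 to compound 4 (within the scatter), with compound 2 at 5.2 and compound 4 at 5.2, so the large gap in circulating compound comes with no difference in that read-out. The gap in the Rattus norvegicus assay can be placed on the configuration at these two ring carbons alone, because nothing else separates the pair: the fact that compounds 2 and 4 differ only in the configuration as drawn.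

The compounds shown leave open whether inverting just one of the two ring carbons would account for part or all of this gap, and whether the same inversion would move the Rattus norvegicus assay as far in compound 1 or compound 3, and they do not tell whether absorption, clearance or something else lies behind it. They also leave open how an amine or a carboxylic acid added to the shared core would read in the Rattus norvegicus assay under either configuration.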